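The compounds below may be only part of what the source reports. "The series", "measured", "known", "first", "only" and "open" are said of these compounds alone.

Compound 1 `N[C@H]1CC[C@H](Nc2c(C(=O)NCc3ccc(Cl)cc3)nc(Br)c3cccnc23)CC1` is the reference point here. In a functional assay on MDA-MB-435 cells (Homo sapiens) for cytotoxicity, read by MTT assay, with a stated time of 72 h (a higher number here means a weaker inhibitor, a lower number a stronger inhibitor), compound 1 gives 1000 nM, the lowest number among the three measured compounds. Compound 2 `N[C@H]1CC[C@H](Nc2c(C(=O)NCc3ccc(Oc4ccccc4)cc3)nc(Br)c3cccnc23)CC1` gives 4000 nM, and compound 3 `N[C@H]1CC[C@H](NC(=O)c2nc(Br)c3cccnc3c2NCc2ccc(F)cc2)CC1`, in which the amide and the amine are arranged differently on the shared core, gives 6600 nM; the gaps from compound 1 to both lie beyond the scatter, so compound 1 is the strongest inhibitor of the three on these numbers.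

Compound 4 `N[C@H]1CC[C@H](Nc2c(C(=O)NCc3cccs3)nc(Br)c3cccnc23)CC1` has not yet been measured. It differs from compound 1 in one place: thiophen-2-yl in place of 4-chlorophenyl on a saturated chain carbon bound to an amide-type nitrogen. Among the compounds with values here, the only measured step at the same part of the molecule is a 4.0-fold higher number from compound 1 to compound 2 (0.60 log units; beyond the scatter), where the change was an exchange of one substituent on the aromatic carbon for another, while here the whole 4-chlorophenyl ring is replaced by thiophen-2-yl. Within the data shown here, no measured pair shows exactly this exchange, so the expectation rests on the direction of that single step. A modest loss is expected, and the estimate for compound 4 is 2000 nM, with a likely range from 800 nM to 5000 nM; this means an expected step of a 2.0-fold higher number from compound 1 to compound 4 (0.30 log units; within the scatter).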

Compound 4, half-maximal inhibitory concentration: 4100 nM
Estimate against measurement, compound 4: 2.1-fold (0.31 log units) below; the measured number falls inside the stated range.
By their numbers in this assay, from the lowest: compound 1; then compounds 2, 4 and 3 (each within the scatter of the next).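

In this assay, the new change gives a 4.1-fold higher number from compound 1 to compound 4 (0.61 log units; beyond the scatter), so replacing the whole 4-chlorophenyl ring with thiophen-2-yl on this saturated chain carbon bound to an amide-type nitrogen also costs activity. The only earlier step at this part of the molecule, a 4.0-fold higher number from compound 1 to compound 2 (0.60 log units; beyond the scatter), added atoms to the group, whereas thiophen-2-yl has fewer heavy atoms than 4-chlorophenyl, so among these three compounds both a larger and a smaller group give a higher number than the group in compound 1, and compounds 2 and 4 lie within the scatter of each other. Nothing available explains why either change raises the number.

Thiophen-2-yl differs from 4-chlorophenyl in two ways at once, in the ring itself and in the loss of the chlorine, so the compounds shown cannot say which of these matters. A plain phenyl group at the same place would help separate the two, and 4-fluorophenyl or 4-methylphenyl would show whether chlorine itself is needed there.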